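A few compounds are considered here, and "the series" means these few. Any claim that something is new, unique, unknown or untested is made for them only; others in the source may bear on it.

Of the compounds shown here, three have been measured in a functional assay on A-431 cells (Homo sapiens) for cytotoxicity, read by MTT assay, with a stated time of 72 h, tested at 30 uM; a higher number here means more inhibition of growth at the concentration tested, a lower number less inhibition of growth. Compound 2 `N/C(=N\NC(=S)N1CCSCC1)c1ccccn1` gives 81.3%, compound 3 `N/C(=N\NC(=S)N1CCCCC1)c1ccccn1` gives 79.7%, and compound 1 `Cc1cccc(/C(N)=N/NC(=S)N2CCSCC2)n1` gives 64.5%. Compound 3 differs from compound 2 only by piperidin-1-yl in place of thiomorpholin-4-yl on a thiocarbonyl carbon, and this step is a number 1.6 percentage points lower from compound 2 to compound 3 (within the scatter). Compound 1 differs from compound 2 by methyl in place of hydrogen on an aromatic carbon, and that step is a number 16.8 percentage points lower from compound 2 to compound 1 (beyond the scatter).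

Compound 4 `Cc1ccnc(/C(N)=N/NC(=S)N2CCCCC2)c1` is not yet measured. It differs from compound 3 by methyl in place of hydrogen on an aromatic carbon, the same kind of change as from compound 2 to compound 1, though here the methyl sits meta to a large group and opposite the ring nitrogen rather than next to the ring nitrogen. Because the earlier step was a number 16.8 percentage points lower from compound 2 to compound 1 (beyond the scatter), a smaller lowering is expected for compound 4, a number 11.7 percentage points lower from compound 3 to compound 4 (beyond the scatter), giving an estimate of 68% in this assay, between 52% and 84%.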

Compound 4, percent growth inhibition at one concentration: 62.8%
For compound 4 the middle estimate is 5.2 percentage points above the measured one; the range from low to high includes it.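

Methyl in place of hydrogen on an aromatic carbon gives a number 16.9 percentage points lower from compound 3 to compound 4 (beyond the scatter) in this assay and this matches the earlier step on the other core: the same change on two cores in this assay, a number 16.8 percentage points lower (beyond the scatter) from compound 2 to compound 1 and a number 16.9 percentage points lower (beyond the scatter) from compound 3 to compound 4, 0.1 percentage points apart, within the scatter of two such steps. The lowering therefore carried over from a thiomorpholin-4-yl compound to a piperidin-1-yl compound, with the methyl opposite the ring nitrogen in compound 4. Going by these compounds alone, this rests on only two pairs, however, and it does not show why the number falls or that the same step would appear on any other core.

The compounds shown leave open whether an ethyl chain, a chlorine atom or a methoxy group in place of the methyl would also lower the number. They also leave open what a methyl would do on the other aromatic carbons.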